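Propylamino for benzylamino: the limit is expected to hold

A few compounds are considered here, and "the series" means these few. Any claim that something is new, unique, unknown or untested is made for them only; others in the source may bear on it.

Compound 1 `CN(C)c1nc(N)nc2c1ncn2/C=C1/CC1(CO)CO` and compound 2 `Nc1nc(NCc2ccccc2)c2ncn(/C=C3/CC3(CO)CO)c2n1` share a core and differ in one substituent. In an ADME assay on CCRF-HSB-2 cells (Homo sapiens) for cytotoxicity, with a stated time of 7 days (on this read-out lower numbers stand for higher toxicity in this test and higher numbers for lower toxicity in this test), compound 1 gives > 20000 nM, which is a limit of the assay and not a number. Compound 2 gives > 20000 nM, which is also a limit. Among the measured compounds shown here, compound 2 therefore has no measured number, and the series so far stands at the limit of > 20000 nM in this assay, at which 2 of the 2 values shown sit.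

Compound 3 `CCCNc1nc(N)nc2c1ncn2/C=C1/CC1(CO)CO` differs from compound 2 by ethyl in place of phenyl on a saturated chain carbon bound to a nitrogen on an aromatic ring. In words, this is ethyl in place of phenyl on a saturated chain carbon bound to a nitrogen on an aromatic ring, or benzylamino to propylamino.

For the measured compounds named here, the only measured step that bears on this change is a step that the two limits leave unreadable from compound 1 to compound 2. It altered the same substituent but gives no size to carry over. No step beyond the scatter is expected in this assay, and another report as a limit is the likely outcome. The estimated step is a step that the limit leaves unreadable from compound 2 to compound 3. Compound 3 is expected at 30000 nM, with an estimated range of 15000 nM to 80000 nM.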

Compound 3, half-maximal cytotoxic concentration: > 20000 nM
Compound 3: a limit, no number; the forecaster's own chance of this, stated with the estimate: 85%; the middle value is on the limit's open side.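

In this assay compound 3 gives > 20000 nM as a limit and not a number. Compound 1 and compound 2 also stand only as limits, so no new step can be read among the three compounds. The compounds shown leave open whether any substituent at this place on the shared core gives a measured number in this read-out.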